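The source may hold more compounds than are shown below. What is called first, only, known or untested is meant among the compounds shown, and "the series" means these compounds.

- Compound 1 `OC[C@H]1O[C@@H](n2cnc3c(NCc4ccc(F)cc4)ncnc32)[C@H](O)[C@@H]1O`: 2700 nM
- Compound 2 `OC[C@H]1O[C@@H](n2cnc3c(NCc4cccc(Br)c4)ncnc32)[C@H](O)[C@@H]1O`: 19700 nM

In a functional assay on K562 cells (Homo sapiens) for antiproliferative activity, with a stated time of 72 h (a higher number here means a weaker inhibitor, a lower number a stronger inhibitor), compound 2 at 19700 nM has the higher of the two numbers, which makes it the weaker inhibitor of this pair. The two compounds share a core and differ only in the aromatic group of the side chain, and the gap between them is a 7.3-fold higher number from compound 1 to compound 2 (0.86 log units; beyond the scatter).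

The next compound, compound 3 `COc1ccccc1CNc1ncnc2c1ncn2[C@@H]1O[C@H](CO)[C@@H](O)[C@H]1O`, changes that same group again: 2-methoxyphenyl replaces 3-bromophenyl on a saturated chain carbon bound to a nitrogen on an aromatic ring (2-methoxyphenyl in place of 3-bromophenyl on a saturated chain carbon bound to a nitrogen on an aromatic ring).

For the measured compounds named here, only one measured step bears on this change, namely a 7.3-fold higher number from compound 1 to compound 2 (0.86 log units; beyond the scatter). It shows that a swap at this place can move the number beyond the scatter, but it says nothing directly about a methoxy group. Compound 2 sits at the upper end of a very small set, so a drift back towards compound 1 seems more likely than a further rise, though only modestly so.

The expected change is a 2.8-fold lower number from compound 2 to compound 3 (0.45 log units; beyond the scatter), and this is a rough estimate. For compound 3 the estimated value is 7000 nM, with an expected range of 1800 nM to 25000 nM.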

Compound 3, half-maximal inhibitory concentration: 89000 nM
For compound 3 the middle estimate is 13-fold (1.10 log units) below the measured one; measured number outside the range, above it.
By their numbers in this assay, from the lowest: compound 1; then compound 2; then compound 3.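

In this assay the second swap at this place moves the number further up, with a 4.5-fold higher number from compound 2 to compound 3 (0.65 log units; beyond the scatter) and so a second step beyond the scatter in the same direction. Measured against the best of the set, the change is a 33-fold higher number from compound 1 to compound 3 (1.52 log units; beyond the scatter) and counts as large, so the aromatic group on the side chain alone can decide much of the activity while the shared core stays the same, and the 2-methoxyphenyl group gives the weakest inhibitor of the three. Nothing at hand accounts for this rise.

The three compounds change the kind of substituent and its place on the ring at the same time, so they leave open which of the two drives the differences, and a 2-bromophenyl or 3-methoxyphenyl group would be needed to pull them apart. Also open, on these data alone, is how a plain phenyl group with no substituent, an amine on the ring or a longer chain to the ring would fare, and whether any of them would beat the 4-fluorophenyl group of compound 1.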